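Carbamate series: aryl ketone in place of the thioether

A few compounds are considered here, and "the series" means these few. Any claim that something is new, unique, unknown or untested is made for them only; others in the source may bear on it.

Three carbamate-substituted compounds have been measured in a functional assay on PC-3 cells (Homo sapiens) for cytotoxicity, read by MTT assay, with a stated time of 72 h, tested at 10 uM; on this read-out higher numbers stand for a weaker effect at the one concentration tested and lower numbers for a stronger effect. Compound 1 `O=C(Nc1nc2cc(Sc3ccccc3)ccc2[nH]1)OC1COC1` gives 87.8%, compound 3 `CCCSc1ccc2[nH]c(NC(=O)OC3COC3)nc2c1` gives 84.5%, and compound 2 `CCCSc1ccc2[nH]c(NC(=O)OCCCN(C)C)nc2c1` gives 78.3%. Compound 2 stands at the smallest number of the three, but both gaps lie within the scatter: a number 6.2 percentage points higher from compound 2 to compound 3 (within the scatter) and, between the two oxetan-3-yl carbamates, a number 3.3 percentage points lower from compound 1 to compound 3 (within the scatter). On these numbers the set is flat, and all three sit at weak effect.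

Compound 4 `CN(C)CCCOC(=O)Nc1nc2cc(C(=O)c3ccc(F)cc3)ccc2[nH]1` differs from compound 2 at one position: (4-fluorophenyl)carbonyl in place of propylsulfanyl on an aromatic carbon. The group on the carbamate oxygen, 3-(dimethylamino)propyl, is kept from compound 2. For the measured compounds named here, no measured step exchanges the propylsulfanyl for a carbonyl-linked group; the only step at this aromatic carbon, propyl in place of phenyl on a sulfur from compound 1 to compound 3, stayed within the scatter, and the step from compound 2 to compound 3 concerns the other end of the molecule. There is therefore no measured basis for expecting a shift beyond the scatter in this assay, although the entering group is the largest change so far seen in the set.

The expected step is a number 0.3 percentage points lower from compound 2 to compound 4 (within the scatter). Compound 4 is estimated at 78%, within a range of 55% to 95%.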

Compound 4, a percentage reported as activity, at one concentration (the size of the read-out at that concentration, not a potency): 86.6%
The estimate for compound 4 lay 8.6 percentage points below the measured number; the measured number falls inside the stated range.
By their numbers in this assay, from the lowest: compounds 2, 3, 4 and 1 (each within the scatter of the next).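

In this assay, for the compounds shown here, the exchange at this aromatic carbon gives a number 8.3 percentage points higher from compound 2 to compound 4 (within the scatter), so tolerance at this position now extends beyond the sulfur-linked groups of the earlier compounds to a carbonyl-linked aryl group, with no shift beyond the scatter. The change is also a large one in size, with 9 heavy atoms and a six-membered aromatic ring entering where propylsulfanyl brought 4 heavy atoms and no ring, yet compound 4, like compound 2, remains at weak effect at the one concentration tested. No evidence on hand bears on this result, so the step can be recorded only as a number.

On these data alone, it remains open whether a group of another kind on this aromatic carbon, such as a primary amine or a carboxylic acid, would move the read-out beyond the scatter, and whether the fluorine of the (4-fluorophenyl)carbonyl group matters at all, which a comparison with the plain benzoyl group would address. Also open, as far as these compounds go, is how (4-fluorophenyl)carbonyl behaves when the 3-(dimethylamino)propyl group on the carbamate oxygen is replaced by oxetan-3-yl.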